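Removing the Pyrrolidinylmethyl Group: A Small Expected Response

This account rests on a few compounds, and the source may have more. Where it says the series, first, only, none or still open, it means among the compounds named here.

Measured compounds:
- compound 1 `COc1cc(O)c(C(=O)c2ccccc2Br)c(OC)c1`: 7%
- compound 2 `COc1cc(OC)c(C(=O)c2ccccc2F)c(O)c1CN1CCCC1`: 15%
- compound 3 `COc1cc(OC)c(C(=O)c2cccc(Cl)c2)c(O)c1CN1CCCC1`: 41%

These three were tested in a functional assay on THP-1 cells (Homo sapiens) for inhibition, read by ELISA, with stated times of 30 min and 24 h, tested at 1 uM; on this read-out lower numbers stand for a weaker effect and higher numbers for a stronger effect at the one concentration tested. Going by the values given here, compound 2 sits within the scatter of compound 1 and below compound 3, the only step that is beyond the scatter: a number 26 percentage points higher from compound 2 to compound 3 (beyond the scatter), a change on the carbonyl side.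

Compound 4 `COc1cc(O)c(C(=O)c2ccccc2F)c(OC)c1` differs from compound 2 on the other side of the molecule: hydrogen in place of (pyrrolidin-1-yl)methyl on an aromatic carbon. Among the compounds with values here, no measured step changes this group, so the one step known, from compound 2 to compound 3, does not bear on it. Compound 1, which also lacks this group, shows a number within the scatter of compound 2. Compound 4 is therefore expected to stay low, estimated at 9% (range 0% to 22%). This means an expected step of a number 6 percentage points lower from compound 2 to compound 4 (within the scatter), within the scatter.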

Compound 4, a percentage reported as activity, at one concentration (the size of the read-out at that concentration, not a potency): 11%
Compound 4: middle estimate off by 2 percentage points, on the low side; low and high end bracket the measured number.
By their numbers in this assay, from the lowest: compounds 1, 4 and 2 (each within the scatter of the next); then compound 3.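

Leaving hydrogen in place of (pyrrolidin-1-yl)methyl gives a number 4 percentage points lower from compound 2 to compound 4 (within the scatter) in this assay, so with this 2-fluorophenyl carbonyl the group makes no readable difference at this low level. Among the compounds without that group, fluoro in place of bromo gives a number 4 percentage points higher from compound 1 to compound 4 (within the scatter), so this swap cannot be told apart either. No measurement here explains these results.

As far as these compounds go, whether losing the group would matter with the 3-chlorophenyl of compound 3 stays open. So does the effect of another amine at this position, such as a piperidinylmethyl or dimethylaminomethyl group.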